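Swapping the Hydrazide for an Aryl Ketone

The source may report more compounds than this note shows. Statements on the series, on what has been measured and on what is new or still open speak of the compounds shown alone.

compound 1 `NNC(=O)c1c(N)sc2c1CCCCCC2`: 48%
compound 2 `Nc1sc2c(c1C(=O)NNc1ccccc1)CCCCCC2`: 47%
compound 3 `Nc1sc2c(c1C(=O)c1cccc(C(F)(F)F)c1)CCC2`: 75%

In a functional assay on CHO cells for agonist activity at adenosine receptor A1 (Homo sapiens), read by ERK phosphorylation, tested at 3 uM (a lower number here means a weaker effect, a higher number a stronger effect of the compound at the concentration tested), compound 1 gives 48%; compound 2 lies within the scatter of it, while compound 3 stands beyond it on the high side. Going by the values given here, the only measured step, a number 1 percentage points lower from compound 1 to compound 2 (within the scatter), alters the group on the carbonyl carbon and leaves the read-out unchanged beyond the scatter. Compound 4 `Cc1ccc(C(=O)c2c(N)sc3c2CCCCCC3)cc1` differs from compound 1 in this way: 4-methylphenyl in place of aminoamino on a carbonyl carbon. Among the compounds with values here, no measured step covers this change. Compound 3, which also carries a phenyl ring on the carbonyl carbon but has a different core, shows 75%, which hints at a rise, though it differs in more than one place. Compound 4 is therefore expected to give 65%, between 40% and 85%. The expected step is a number 17 percentage points higher from compound 1 to compound 4 (beyond the scatter).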

Compound 4, a percentage reported as activity, at one concentration (the size of the read-out at that concentration, not a potency): 56%
Compound 4: middle estimate off by 9 percentage points, on the high side, within the range that was stated.
By their numbers in this assay, from the lowest: compounds 2, 1 and 4 (each within the scatter of the next); then compound 3.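

Putting 4-methylphenyl in place of aminoamino on a carbonyl carbon gives a number 8 percentage points higher from compound 1 to compound 4 (within the scatter) in this assay. So the hydrazide nitrogens, with their hydrogen-bond donors, can be swapped on the core of compound 1 for a carbon-only aromatic ring without a change beyond the scatter. No supporting data explain this result.

Still open, on these data alone, is what a smaller group, such as a methyl, would give on this carbonyl carbon. A ring carrying a carboxylic acid or an amine also remains untested by the compounds shown here.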